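The source may hold more compounds than are shown below. What is called first, only, known or untested is meant among the compounds shown, and "the series" means these compounds.

In a physicochemical assay for lipophilicity, at pH 7.4 (a higher number here means a more lipophilic compound, a lower number a more polar compound), compound 1, `Cc1cc(C(N)=O)nn1Cc1cc(Cl)ccc1OCc1ccccc1`, gives 3.7. Among the numbers shown this is the higher one; compound 3, `Cc1cc(C(=O)Nc2ccc(F)cc2)nn1Cc1cc(Cl)ccc1OCc1ccccc1`, gives 3, which is a number 0.70 log units lower from compound 1 to compound 3 (beyond the scatter). Compound 2, `Cc1cc(C(=O)Nc2ccccc2)nn1Cc1cc(Cl)ccc1OCc1ccccc1`, gives only a limit of the assay, > 3.7, so its exact number is open, as the limit of > 3.7 in this assay, at which 1 of the 3 values shown sits, shows. Compound 4, `Cc1cc(NC(=O)C(C)C)nn1Cc1cc(Cl)ccc1OCc1ccccc1`, is unmeasured; it differs from compound 1 by (isopropylcarbonyl)amino in place of carbamoyl on an aromatic carbon. The measured steps, a number no lower from compound 1 to compound 2 (the limit leaves the size open) and a number at least 0.70 log units lower from compound 2 to compound 3 (beyond the scatter), all change the amide substituent or a ring hydrogen rather than the amide itself, so none bears closely on this change. Compound 4 is therefore expected to land near compound 1, with a step of a number 0.20 log units higher from compound 1 to compound 4 (within the scatter), giving an estimate of 3.9, between 3.4 and 4.4.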

Compound 4, distribution coefficient: > 3.7
Compound 4: only a limit was reported (the forecaster's own chance of this, stated with the estimate: 50%); the middle value does not contradict the limit.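

In this assay, (isopropylcarbonyl)amino in place of carbamoyl on this aromatic carbon gives a number no lower from compound 1 to compound 4 (the limit leaves the size open), the first change shown to the amide itself. Replacing (4-fluorophenyl)carbamoyl at the same position gives a number at least 0.70 log units higher from compound 3 to compound 4 (beyond the scatter), so this change can be told apart from the scatter in that comparison. The value of compound 4 is a limit, as is that of compound 2, so the step between them cannot be read: the limit of > 3.7 in this assay, at which 2 of the 4 values shown sit.

As far as these compounds go, how large the step from carbamoyl really is stays open. So does how a simple amine or a carboxylic acid on this aromatic carbon would read in this assay.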